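Replacing a chlorinated bicyclic sulfur substituent with a small triazole

A few compounds are considered here, and "the series" means these few. Any claim that something is new, unique, unknown or untested is made for them only; others in the source may bear on it.

Of the compounds shown here, three sharing one core have been tested in a functional assay on MCF7 cells (Homo sapiens) for cytotoxicity, read by MTT assay, with a stated time of 24 h, tested at 16 ug/mL; a higher number here means a stronger effect of the compound at the concentration tested, a lower number a weaker effect. Compound 1 `Cn1c(-c2ccc(NC(=O)CSc3nc4ccccc4o3)cc2)nc(-c2ccccc2)c1-c1ccccc1` gives 56%. Compound 2 `Cn1c(-c2ccc(NC(=O)CSc3nc4cc(Cl)ccc4o3)cc2)nc(-c2ccccc2)c1-c1ccccc1` gives 40%, and compound 3 `Cn1c(-c2ccc(NC(=O)CSc3nc4ccccc4s3)cc2)nc(-c2ccccc2)c1-c1ccccc1` gives 50.3%. Compound 2 stands lowest of the three: it is separated from compound 3 by a number 10.3 percentage points higher from compound 2 to compound 3 (beyond the scatter) and from compound 1 by a number 16 percentage points lower from compound 1 to compound 2 (beyond the scatter), both beyond the scatter.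

Compound 4 `Cn1cnnc1SCC(=O)Nc1ccc(-c2nc(-c3ccccc3)c(-c3ccccc3)n2C)cc1` has not been measured. It differs from compound 2 by 4-methyl-4H-1,2,4-triazol-3-yl in place of 5-chloro-1,3-benzoxazol-2-yl on a sulfur. Among the measured compounds shown here, two measured steps bear on this change. The step of a number 16 percentage points lower from compound 1 to compound 2 (beyond the scatter) shows that adding chloro on an aromatic carbon lowered the read-out, and the step of a number 10.3 percentage points higher from compound 2 to compound 3 (beyond the scatter) shows that exchanging the whole 5-chloro-1,3-benzoxazol-2-yl group for another bicyclic group raised it again. Compound 4 removes the 5-chloro-1,3-benzoxazol-2-yl group entirely, so a modest rise from compound 2 is expected, though nothing measured resembles 4-methyl-4H-1,2,4-triazol-3-yl and the range is wide. Compound 4 is therefore estimated at 48%, between 30% and 65%, a step of a number 8 percentage points higher from compound 2 to compound 4 (within the scatter).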

Compound 4, a percentage reported as activity, at one concentration (the size of the read-out at that concentration, not a potency): 61.2%
Compound 4: the middle estimate sits 13.2 percentage points below what was measured; the measured number falls inside the stated range.
By their numbers in this assay, from the lowest: compound 2; then compounds 3, 1 and 4 (each within the scatter of the next, the first and the last beyond it).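

The sulfur position accepts a smaller group than the bicyclic ones: 4-methyl-4H-1,2,4-triazol-3-yl, with a single five-membered aromatic ring, gives a number 21.2 percentage points higher from compound 2 to compound 4 (beyond the scatter) and a number 10.9 percentage points higher from compound 3 to compound 4 (beyond the scatter) in this assay. Measured against the unchlorinated 1,3-benzoxazol-2-yl group, the same change gives a number 5.2 percentage points higher from compound 1 to compound 4 (within the scatter), so among these four compounds a fused six-membered ring on the sulfur is not needed to keep the read-out. No measurement is at hand that would explain why the triazole behaves this way.

Still open, from the compounds shown here alone, is whether the methyl on the triazole matters, and whether a carboxylic acid or an amine such as morpholine in place of the triazole would hold the read-out. Going by these compounds, these numbers come from one concentration, so how the compounds compare in potency also remains unknown.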